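Working notes: from compound 2 to compound 4

The source may report more compounds than this note shows. Statements on the series, on what has been measured and on what is new or still open speak of the compounds shown alone.

In a functional assay on Jurkat cells (Homo sapiens) for cytotoxicity, read by MTT assay, with a stated time of 24 h (on this read-out higher numbers stand for an effect only at larger amounts of compound and lower numbers for an effect already at smaller amounts), compound 1 (`CCOC(=O)c1cc([Se]c2ccccc2)c2cc(Br)ccc2n1`) gives 20800 nM and compound 3 (`COc1ccc2nc(-c3c(C)cccc3C)cc([Se]c3ccccc3)c2c1`) gives 26900 nM on the same read-out. Compound 2 (`CCOC(=O)c1cc([Se]c2ccc(F)cc2)c2cc(OC)ccc2n1`) stands highest of the three at 134000 nM and lies beyond the scatter from both others. Compound 4 (`CCOC(=O)c1cc([Te]c2ccccc2)c2cc(OC)ccc2n1`) is reached by one change: a group of 7 heavy atoms (6 carbon, 1 tellurium; one six-membered aromatic ring of carbon only) in place of a group of 8 heavy atoms (6 carbon, 1 fluorine, 1 selenium; one six-membered aromatic ring of carbon only), on an aromatic carbon on an aromatic carbon, opposite the ring nitrogen. Among the compounds with values here, no pair of measured compounds differs in one place, and none carries tellurium, so the step has no direct precedent. A drop beyond the scatter in this assay is expected, towards the other two values, with a 4.5-fold lower number from compound 2 to compound 4 (0.65 log units; beyond the scatter) as the estimated step. For compound 4 the estimated value is 30000 nM with an expected range from 7000 nM to 110000 nM in this series.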

Compound 4, half-maximal effective concentration: 77400 nM
The estimate for compound 4 lay 2.6-fold (0.41 log units) below the measured number; measured number inside the range.
By their numbers in this assay, from the lowest: compounds 1 and 3 (each within the scatter of the next); then compounds 4 and 2 (each within the scatter of the next).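

In this assay the tellurium-bearing group in place of the group holding fluorine and selenium, opposite the ring nitrogen, gives a 1.7-fold lower number from compound 2 to compound 4 (0.24 log units; within the scatter) and so leaves no readable shift. This position therefore accepts the exchange of both atoms at once without a change beyond the scatter.

The single step does not separate the loss of fluorine from the move from selenium to tellurium, and an amine or a carboxylic acid on that aromatic ring remains untested among the compounds shown. No available evidence bears on this result.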